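The compounds below may be only part of what the source reports. "The series", "measured", "known", "first", "only" and "open" are said of these compounds alone.

Measured compounds:
- compound 1 `O=c1c(-c2nn[nH]n2)c[nH]c2ccccc12`, 1.25 mg/kg
- compound 2 `Cc1ccc2[nH]cc(-c3nn[nH]n3)c(=O)c2c1`, 1.25 mg/kg
- compound 3 `Cc1cccc2cc(C(=O)O)cnc12`, only a limit in this assay

Two compounds share a core. In a functional assay on the whole organism (strain Sprague-Dawley) for inhibition, with Rattus norvegicus as the target (on this read-out higher numbers stand for an effect only at larger amounts of compound and lower numbers for an effect already at smaller amounts), compound 1 gives 1.25 mg/kg. Compound 2 differs from compound 1 by methyl in place of hydrogen on an aromatic carbon, and in this assay compound 2 gives 1.25 mg/kg, so the step of no change at the digits printed from compound 1 to compound 2 (within the scatter). Compound 3 has a different core; the difference between the two cores is not broken down here. For compound 3 this assay reports only a limit, > 50 mg/kg, which is the edge of what the assay measures and not a number; this is the limit of > 50 mg/kg in this assay, at which 1 of the 3 values shown sits.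

Compound 4 `Cc1ccc2cc(C(=O)O)cnc2c1C` is not yet measured. It differs from compound 3 by methyl in place of hydrogen on an aromatic carbon. Among the measured compounds shown here, this is the same kind of change as the one from compound 1 to compound 2, not the same change: here the entering methyl is ortho to a methyl group, which was not so in the earlier case. Since the earlier step, no change at the digits printed from compound 1 to compound 2 (within the scatter), was flat, the step from compound 3 to compound 4 is expected to be small as well, a step that the limit leaves unreadable from compound 3 to compound 4, though it starts from a limit rather than a number, so the outcome is uncertain. The estimate for compound 4 in this assay is 60 mg/kg, between 20 mg/kg and 150 mg/kg, and most likely the assay will again report only a limit.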

Compound 4, minimum effective dose: 25 mg/kg
Compound 4: the middle estimate sits 2.4-fold (0.38 log units) above what was measured; the range from low to high includes it.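

In this assay, on these data alone, methyl in place of hydrogen on an aromatic carbon gives an at least 2.0-fold lower number from compound 3 to compound 4 (0.30 log units; that floor lies within the scatter), and since the starting point is a limit of the assay rather than a number, the true size of this step stays unknown. Set beside the same change on the core of compound 1, the result shows that a flat step on one core does not settle what happens on another, yet it cannot show that the two cores respond differently: the same change on two cores in this assay, no change at the digits printed (within the scatter) from compound 1 to compound 2 and an at least 2.0-fold lower number (0.30 log units; that floor lies within the scatter) from compound 3 to compound 4; the limit leaves it open whether they differ The comparison also rests on only two cases with different surroundings, since the entering methyl in compound 4 is ortho to a methyl group, so no general rule for carrying this change between cores can be drawn, and the reading from compound 3 remains tied to a limit: the limit of > 50 mg/kg in this assay, at which 1 of the 4 values shown sits.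

The compounds shown leave open how large the step on the core of compound 3 really is, and whether the same methyl would act alike without the neighbouring methyl group already present on that ring. They also leave open what a different group at this place, such as an amine, a chlorine atom or a longer chain, would do on either core.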